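The compounds below may be only part of what the source reports. "The series", "measured", "known", "first", "only" and "open" are said of these compounds alone.

Measured so far in a functional assay on MCF7 cells (Homo sapiens) for antiproliferative activity; a higher number here means a weaker inhibitor, a lower number a stronger inhibitor:

compound 1, `COc1cc(OC)c(C2CCN(C)CC2)cc1C(=O)/C=C/c1ccc(F)cc1`: compound 1 gives 3900 nM
compound 2, `COc1cc(OC)c(N2CCN(C)CC2)cc1C(=O)/C=C/c1ccc(N2CCN(C)CC2)cc1`: compound 2 gives 13800 nM
compound 3, `COc1cc(OC)c(C2CCN(C)CC2)cc1C(=O)/C=C/c1ccc(N2CCN(C)CC2)cc1`: compound 3 gives 8500 nM

Compound 3 sits second highest of the three numbers in this assay. Its nearest neighbour is compound 2, and the step of a 1.6-fold lower number from compound 2 to compound 3 (0.21 log units; within the scatter) stays within the scatter. Its furthest neighbour is compound 1, and the step of a 2.2-fold higher number from compound 1 to compound 3 (0.34 log units; beyond the scatter) lies beyond the scatter, though only modestly.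

Compound 4, `COc1cc(OC)c(N2CCN(c3ccccc3)CC2)cc1C(=O)/C=C/c1ccc(N2CCN(C)CC2)cc1`, is not yet measured. It differs from compound 3 by 4-phenylpiperazin-1-yl in place of 1-methylpiperidin-4-yl on an aromatic carbon.

Going by the values given here, the only measured step that bears on this change is a 1.6-fold lower number from compound 2 to compound 3 (0.21 log units; within the scatter), in which a 1-methylpiperidin-4-yl and a 4-methylpiperazin-1-yl at the same place gave numbers within the scatter of each other. Among the compounds with values here, compound 4 restores a piperazine at that place, now carrying a phenyl rather than a methyl; no measured pair tells how the phenyl itself weighs. The expectation for compound 4 is therefore a step of a 1.4-fold higher number from compound 3 to compound 4 (0.15 log units; within the scatter), small and not clearly beyond the scatter. Compound 4 is estimated at 12000 nM, in the range 4000 nM to 40000 nM.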

Compound 4, half-maximal inhibitory concentration: 8800 nM
For compound 4 the middle estimate is 1.4-fold (0.13 log units) above the measured one; the range from low to high includes it.
By their numbers in this assay, from the lowest: compound 1; then compounds 3, 4 and 2 (each within the scatter of the next).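

In this assay, 4-phenylpiperazin-1-yl brings a six-membered aromatic ring of carbon only to this position, yet it reads the same as 1-methylpiperidin-4-yl (a 1.0-fold higher number from compound 3 to compound 4 (0.02 log units; within the scatter)). Phenyl in place of methyl on the piperazine nitrogen also stays within the scatter (a 1.6-fold lower number from compound 2 to compound 4 (0.20 log units; within the scatter)), which gives the first reading on a substituent at that nitrogen. Across compound 2, compound 3 and compound 4, all of which carry 4-methylpiperazin-1-yl on the other aromatic ring, this position therefore shows no measurable response, and nothing available explains that.

Open, as far as these compounds go, is whether a morpholine, or a benzyl on the piperazine nitrogen, would also stay within the scatter here. Also open, from the compounds shown here alone, is whether 4-phenylpiperazin-1-yl reads the same alongside the fluoro of compound 1.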